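Halogen swap on the fused ring: compound 3 to compound 4

This account rests on a few compounds, and the source may have more. Where it says the series, first, only, none or still open, it means among the compounds named here.

Measured in a functional assay (aorta) with Rattus norvegicus as the target; a higher number here means that more compound is needed for the effect, a lower number that less compound is needed:
compound 1 `Cc1ccccc1NC(=O)NC1CC(C)(C)Oc2ccc(Br)cc21` gives > 30000 nM, a limit of this assay.
compound 2 `Cc1cccc(NC(=O)NC2CC(C)(C)Oc3ccc(Br)cc32)c1` gives > 10000 nM, a limit of this assay.
compound 3 `CC1(C)CC(NC(=O)Nc2ccc(Cl)cc2)c2cc(Cl)ccc2O1` gives > 300000 nM, a limit of this assay.

Every value shown is a limit, so compound 3 has no position on a scale of numbers; it sits at the limit of > 300000 nM in this assay, at which 1 of the 3 values shown sits, while the other two sit at the limit of > 30000 nM in this assay, at which 1 of the 3 values shown sits, and (the limit of > 10000 nM in this assay, at which 1 of the 3 values shown sits). Within the data shown here, the only step between measured compounds, a step that the two limits leave unreadable from compound 1 to compound 2, concerns the aryl urea end and is itself unreadable, so no measured step reports a size at all.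

Compound 4 `CC1(C)CC(NC(=O)Nc2ccc(Cl)cc2)c2cc(Br)ccc2O1` differs from compound 3 by bromo in place of chloro on an aromatic carbon. Among the measured compounds shown here, no measured step touches this position, and the one recorded step gives no readable magnitude. Nothing in the series therefore points to a change beyond the scatter in this assay. Compound 4 is expected at 300000 nM (range 100000 nM to 1000000 nM), most likely reported again as a limit. The implied step is estimated as a number no higher from compound 3 to compound 4 (the limit leaves the size open), within the scatter.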

Compound 4, half-maximal effective concentration: > 300000 nM
Compound 4: only a limit was reported; the forecaster's own chance of this, stated with the estimate: 80%; the middle value lies on the limit itself.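

Among these compounds, no step to compound 4 from compound 1, compound 2 or compound 3 can be read: all four values are limits. Left open is whether bromo in place of chloro changes the concentration needed in this assay, and where any of these compounds sits as an actual number.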